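Working notes: from compound 2 to compound 3

A few compounds are considered here, and "the series" means these few. Any claim that something is new, unique, unknown or untested is made for them only; others in the source may bear on it.

Measured in an ADME assay on microsomes from liver (Mus musculus) for metabolic stability, read by mass spectrometry, with a stated time of 40 min, tested at 1 uM; on this read-out lower numbers stand for a less stable compound and higher numbers for a more stable compound:
- compound 1 `COc1cc(N2CCN(CC3CCOC3)CC2)ccc1Nc1nc(NC2CCCCC2)c2nc[nH]c2n1` gives 59% of parent
- compound 2 `COc1cc(N2CCC(CC(=O)N3CCOCC3)CC2)ccc1Nc1nc(NC2CCCCC2)c2nc[nH]c2n1` gives 61% of parent

Compound 2 stands level with compound 1, as the two values lie within the scatter of each other. Going by the values given here, no measured pair yet differs in one place only, so no measured step is available as a guide.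

Compound 3 `COc1cc(N2CCC(C(=O)N3CC(O)C3)CC2)ccc1Nc1nc(NC2CCCCC2)c2nc[nH]c2n1` has (3-hydroxyazetidin-1-yl)carbonyl in place of ((morpholin-4-yl)carbonyl)methyl on a saturated ring carbon.

Among the compounds with values here, the only evidence is that compound 1 at 59% and compound 2 at 61% stay within the scatter with different side groups on the shared core. The expected change is a number 3 percentage points higher from compound 2 to compound 3 (within the scatter) in this assay, with no step beyond the scatter. Compound 3 is estimated at 64% in this assay, with an expected range of 48% to 80%.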

Compound 3, percent of the compound remaining: 65%
Beside the measured number, compound 3's estimate is 1 percentage points below it; the measured number falls inside the stated range.
By their numbers in this assay, from the lowest: compounds 1, 2 and 3 (each within the scatter of the next).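

In this assay, going by these compounds alone, the first step between compounds differing in one place reads a number 4 percentage points higher from compound 2 to compound 3 (within the scatter) and so gives this position its first direct comparison. On a saturated ring carbon of a six-membered non-aromatic ring with 1 nitrogen, (3-hydroxyazetidin-1-yl)carbonyl can stand in place of ((morpholin-4-yl)carbonyl)methyl with no step beyond the scatter, although a four-membered ring with 1 hydrogen-bond donor replaces a six-membered ring with 2 hetero atoms and no donor. No measured finding offers an explanation for this result.

As far as these compounds go, whether a carboxylic acid or a primary amine on this ring carbon would give a step beyond the scatter stays open. This single step changes the ring and the methyl link together, so the share of each cannot be told apart.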